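Second fluoro on the benzamide ring: compound 4

The compounds below may be only part of what the source reports. "The series", "measured", "known", "first", "only" and "open" are said of these compounds alone.

Measured compounds:
compound 1 `O=C(Nc1cccc(-c2oc3cc(-c4ccc(F)cc4)ccc3c(=O)c2O)c1)c1ccccc1F` — 10100 nM
compound 2 `Cc1cccc(C(=O)Nc2cccc(-c3oc4cc(-c5ccc(F)cc5)ccc4c(=O)c3O)c2)c1` — 13500 nM
compound 3 `O=C(Nc1cccc(-c2oc3cc(-c4ccc(F)cc4)ccc3c(=O)c2O)c1)c1cccc(F)c1` — 15500 nM

In a functional assay on HepG2 cells (Homo sapiens) for antiproliferative activity, read by CCK-8 assay, with a stated time of 72 h (a lower number here means a stronger inhibitor, a higher number a weaker inhibitor), all three numbers fall within the scatter of one another. Compound 3 is not set apart from compound 1 or compound 2: the steps of a 1.5-fold higher number from compound 1 to compound 3 (0.19 log units; within the scatter) and a 1.1-fold higher number from compound 2 to compound 3 (0.06 log units; within the scatter) are both within the scatter, as is a 1.3-fold higher number from compound 1 to compound 2 (0.13 log units; within the scatter). The varied part is the aryl on the carbonyl carbon of the amide, and neither the change from 2-fluorophenyl to 3-fluorophenyl nor that from 3-methylphenyl to 3-fluorophenyl moved the number beyond the scatter.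

Compound 4 `O=C(Nc1cccc(-c2oc3cc(-c4ccc(F)cc4)ccc3c(=O)c2O)c1)c1cc(F)cc(F)c1` extends this with fluoro in place of hydrogen on an aromatic carbon, turning the 3-fluorophenyl into a 3,5-difluorophenyl. The nearest precedents are the steps onto the same aryl, a 1.5-fold higher number from compound 1 to compound 3 (0.19 log units; within the scatter) and a 1.1-fold higher number from compound 2 to compound 3 (0.06 log units; within the scatter), both small. Among the compounds with values here, no measured step shows a second substituent on this ring, so no direction is supported. The expectation is therefore a step of a 1.1-fold lower number from compound 3 to compound 4 (0.04 log units; within the scatter), that is, none beyond the scatter. For compound 4 the estimate in this assay is 14000 nM, with a range of 7000 nM to 30000 nM.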

Compound 4, half-maximal inhibitory concentration: 4960 nM
For compound 4 the middle estimate is 2.8-fold (0.45 log units) above the measured one; the measured number lies below the stated range.
By their numbers in this assay, from the lowest: compound 4; then compounds 1, 2 and 3 (each within the scatter of the next).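

In this assay, within the data shown here, a second fluoro on the 3-fluorophenyl, giving the 3,5-difluorophenyl, is the first change on this aryl to move the number beyond the scatter, though only modestly (a 3.1-fold lower number from compound 3 to compound 4 (0.49 log units; beyond the scatter)). The 3,5-difluorophenyl also stands apart from the 3-methylphenyl (a 2.7-fold lower number from compound 2 to compound 4 (0.43 log units; beyond the scatter)) and from the 2-fluorophenyl (a 2.0-fold lower number from compound 1 to compound 4 (0.31 log units; beyond the scatter)), so this ring tolerates more than the within-scatter values of compounds 1, 2 and 3 could show, and the number at this position can be lowered by adding to the ring rather than by moving or exchanging a single substituent. Nothing available accounts for this step.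

Still open, on these data alone, is whether the step belongs to fluoro itself or to any second group in this place, which a chloro, a methoxy or a trifluoromethyl in place of the added fluoro would help to separate. Also open, as far as these compounds go, is whether a third fluoro adds further, and whether an amine or a carboxylic acid on this ring would keep the number of compound 4 in this assay.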